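The source may report more compounds than this note shows. Statements on the series, on what has been measured and on what is new or still open speak of the compounds shown alone.

Measured in an ADME assay on MDBK cells (Bos taurus) for cytotoxicity; on this read-out lower numbers stand for higher toxicity in this test and higher numbers for lower toxicity in this test:
- Compound 1 `Fc1cccc(F)c1Cn1c(-c2c(F)cccc2F)nc2cnccc21`: > 100000 nM
- Compound 2 `Fc1cccc(F)c1Cn1c(-c2c(F)cccc2F)nc2ccncc21`: 99000 nM
- Compound 3 `Cc1ccc(Cn2ccc3nc(-c4ccccc4)nc-3c2)cc1`: > 100000 nM

Compound 3 stands at > 100000 nM, which is a limit of the assay and not a number. Compound 1 also gives a limit, > 100000 nM. Compound 2 gives a number, 99000 nM. Overall, the picture is the limit of > 100000 nM in this assay, at which 2 of the 3 values shown sit.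

The next compound is compound 4 `Clc1ccccc1Cn1ccc2nc(-c3ccccc3)nc-2c1`, which has 2-chlorophenyl in place of 4-methylphenyl on a saturated chain carbon bound to an aromatic nitrogen. Among the compounds with values here, no measured pair shows what a change of this kind does. No step beyond the usual scatter is therefore expected in this assay, in either direction. This expectation rests on compound 3, with its limit of > 100000 nM. Compound 4 may well return a limit too.

The expected change is a number no higher from compound 3 to compound 4 (the limit leaves the size open). For compound 4, the estimate is 100000 nM, with an expected range from 45000 nM to 200000 nM.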

Compound 4, half-maximal cytotoxic concentration: > 100000 nM
Compound 4 was reported as a limit; the forecaster's own chance of this, stated with the estimate: 65%; the middle value sits exactly at the limit.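

In this assay compound 4 gives > 100000 nM, which is a limit of the assay. Compound 3 also gives a limit, > 100000 nM. Within the data shown here, these two limits leave no step readable between compound 3 and compound 4. The compounds shown leave open what 2-chlorophenyl in place of 4-methylphenyl does to this read-out.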